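Aryl Exchange on the Triazole Nitrogen and Expected Potency

A few compounds are considered here, and "the series" means these few. Any claim that something is new, unique, unknown or untested is made for them only; others in the source may bear on it.

Compound 1, `COc1ccc(-n2nncc2CN2C(=O)C3(C(C#N)=C(N)Oc4c3c3nc5ccccc5nc3c3ccccc43)c3ccccc32)cc1`: > 50000 nM in a functional assay on A549 cells (Homo sapiens) for antiproliferative activity, read by MTT assay, with a stated time of 48 h (a higher number here means a weaker inhibitor, a lower number a stronger inhibitor), a limit of the assay.
Compound 2, `Cc1cccc(-n2nncc2CN2C(=O)C3(C(C#N)=C(N)Oc4c(N)cc5nc6ccccc6nc5c43)c3ccccc32)c1`: 12300 nM in this assay.

Among the compounds with values here, compound 2 holds the only number among the values shown; the other entry is a limit, as stated in the limit of > 50000 nM in this assay, at which 1 of the 2 values shown sits. Compound 3, `CC(=O)Nc1ccc(-n2nncc2CN2C(=O)C3(C(C#N)=C(N)Oc4c(N)cc5nc6ccccc6nc5c43)c3ccccc32)cc1`, carries 4-acetamidophenyl in place of 3-methylphenyl on an aromatic nitrogen. Within the data shown here, no measured step between two compounds is available, so the weight of this change cannot be read from a neighbour. The expected step is a 1.5-fold higher number from compound 2 to compound 3 (0.17 log units; within the scatter), towards weaker inhibition, and a limit may be reported instead of a number. Compound 3 is estimated at 18000 nM, expected between 5000 nM and 60000 nM.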

Compound 3, half-maximal inhibitory concentration: > 50000 nM
Compound 3 was reported as a limit (the forecaster's own chance of this, stated with the estimate: 30%); middle value at least 2.7-fold (0.44 log units) away from the limit.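

In this assay, within the data shown here, 4-acetamidophenyl in place of 3-methylphenyl on an aromatic nitrogen gives an at least 4.0-fold higher number from compound 2 to compound 3 (0.60 log units; beyond the scatter), the first measured step at this position, and it runs towards weaker inhibition. Compound 3 gives > 50000 nM, which is a limit of the assay and not a number, so the step has a lower bound but no full size: the limit of > 50000 nM in this assay, at which 2 of the 3 values shown sit.

The compounds shown leave open whether the acetamido group or the loss of the methyl group carries this step. They also leave open how a plain phenyl or an aminophenyl group on the same nitrogen would read.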